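A few compounds are considered here, and "the series" means these few. Any claim that something is new, unique, unknown or untested is made for them only; others in the source may bear on it.

In a functional assay on HCT-8 cells (Homo sapiens) for antiproliferative activity, read by sulforhodamine B assay, with a stated time of 3 days (a lower number here means that less compound is needed, a higher number that more compound is needed for the effect), two compounds that share a core have been measured so far. Compound 1 (`CCCC1=C(OC)C(CCC)(CCC)C(=O)/C(=C(O)\C=C\c2ccccc2)C1=O`) gives 3.5 uM, and compound 2 (`CCCC1=C(OC)C(CCC)(CCC)C(=O)/C(=C(O)\C=C\c2ccc(I)cc2)C1=O`) gives 1.1 uM, the lower of the two numbers. Compound 3 (`CCCC1=C(OC)C(CCC)(CCC)C(=O)/C(=C(O)\C=C\c2ccc(Br)cc2)C1=O`) is still unmeasured and differs from compound 2 as follows: bromo in place of iodo on an aromatic carbon. This is bromo in place of iodo on an aromatic carbon, para to a large group. Among the compounds with values here, only one measured step bears on this change: iodo in place of hydrogen at that same place, a 3.2-fold lower number from compound 1 to compound 2 (0.50 log units; beyond the scatter), a modest step beyond the scatter. Within the data shown here, no bromo compound has been measured, but compound 3 keeps a halogen there, so only part of that step is expected to be given back, towards a higher number and perhaps within the scatter. The expected step is a 1.5-fold higher number from compound 2 to compound 3 (0.16 log units; within the scatter). The estimate for compound 3 is 1.6 uM, with a range of 0.8 uM to 3.2 uM.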

Compound 3, concentration for half-maximal effect: 2.6 uM
Compound 3: the middle estimate sits 1.6-fold (0.21 log units) below what was measured; low and high end bracket the measured number.
By their numbers in this assay, from the lowest: compound 2; then compounds 3 and 1 (each within the scatter of the next).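

In this assay the identity of the halogen on this aromatic carbon matters, not only its presence: replacing iodo with bromo gives a 2.4-fold higher number from compound 2 to compound 3 (0.37 log units; beyond the scatter) and so loses a step beyond the scatter. Set against the unsubstituted parent, bromo gives a 1.3-fold lower number from compound 1 to compound 3 (0.13 log units; within the scatter) and so stays within the scatter, which means that a halogen at this place is not enough on its own to reproduce the effect of iodo. Among these three compounds only compound 2 stands apart, and nothing available accounts for the difference between iodo and bromo.

The compounds shown leave open how chloro, fluoro, a methoxy group or an amine at this place would compare. They also leave open whether the advantage of iodo would persist if the propyl chains of the shared core were replaced.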